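Shortening the side arm: from compound 2 to compound 4

The source may hold more compounds than are shown below. What is called first, only, known or untested is meant among the compounds shown, and "the series" means these compounds.

Compound 1 `CCC[C@@H](CCO)Nc1nc(N)nc(C)c1Cc1ccc(CNCC(N)=O)cc1OC` gives > 10000 nM in an assay on HEK293 cells for agonist activity at Toll-like receptor 8 (Homo sapiens) (on this read-out lower numbers stand for an effect already at smaller amounts and higher numbers for an effect only at larger amounts of compound), a limit of the assay.
Compound 2 `CCC[C@@H](CO)Nc1nc(N)nc(C)c1Cc1ccc(CNCCO)cc1OC` gives 5370 nM in this assay.
Compound 3 `CCC[C@@H](CCO)Nc1nc(N)nc(C)c1Cc1ccc(CNCCC(N)=O)cc1OC` gives > 10000 nM in this assay, again a limit.

Compound 2 is thus the only one of the three with a number; the other two sit at the limit (the limit of > 10000 nM in this assay, at which 2 of the 3 values shown sit). Within the data shown here, the single measured step, a step that the two limits leave unreadable from compound 1 to compound 3, stays unreadable for that reason. Compound 4 `CCC[C@@H](CO)Nc1nc(N)nc(C)c1Cc1ccc(CNC)cc1OC` differs from compound 2 by hydrogen in place of hydroxymethyl on a saturated chain carbon bound to an amine nitrogen. No measured step touches this part of the molecule, so nothing shown says how large a change to expect in this assay or in which direction. Compound 4 is therefore estimated near compound 2, at 6000 nM within 2000 nM to 20000 nM, an expected step of a 1.1-fold higher number from compound 2 to compound 4 (0.05 log units; within the scatter).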

Compound 4, half-maximal effective concentration: 2140 nM
Compound 4: the middle estimate sits 2.8-fold (0.45 log units) above what was measured; measured number inside the range.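

Removing hydroxymethyl from the side arm, so that 2-hydroxyethyl on the amine nitrogen becomes methyl, gives in this assay a 2.5-fold lower number from compound 2 to compound 4 (0.40 log units; beyond the scatter). The end of this arm, with its hydroxyl oxygen, is therefore not needed for a measurable effect at this receptor, and the shorter arm does better here. This is the first step in the series with a readable size, and the other steps cannot be read: the limit of > 10000 nM in this assay, at which 2 of the 4 values shown sit.

As far as these compounds go, whether an ethyl group or a longer plain carbon chain would do as well as methyl stays open. So does what a carboxylic acid at the end of the arm, or a bare amine with no carbon substituent, would do.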